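Acyl variation on the thienopyran carboxamide core

This account rests on a few compounds, and the source may have more. Where it says the series, first, only, none or still open, it means among the compounds named here.

Measured so far:
compound 1 `CC1(C)Cc2c(sc(NC(=O)C3(CO)CC3)c2C(N)=O)C(C)(C)O1` gives 15 nM in an assay on cells for positive allosteric modulation of Cystic fibrosis transmembrane conductance regulator variant F508del (Homo sapiens), with stated times of 10 min and 7 s, in the presence of a further agent that is not named here; on this read-out higher numbers stand for an effect only at larger amounts of compound and lower numbers for an effect already at smaller amounts
compound 2 `CC(C)(C)CC(O)C(=O)Nc1sc2c(c1C(N)=O)CC(C)(C)OC2(C)C` gives 0.54 nM in this assay

Going by the values given here, compound 2 holds the lowest of the two numbers; the only neighbour is compound 1, and the gap is a 28-fold lower number from compound 1 to compound 2 (1.44 log units; beyond the scatter), well beyond the scatter. That single step shows the acyl group on the carbonyl carbon to be a strong lever in this series.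

Compound 3 `Cc1n[nH]c(C(=O)Nc2sc3c(c2C(N)=O)CC(C)(C)OC3(C)C)c1Cl` changes the same spot: a group of 7 heavy atoms (4 carbon, 2 nitrogen, 1 chlorine; one five-membered aromatic ring with 2 hetero atoms) in place of a group of 7 heavy atoms (6 carbon, 1 oxygen; no ring), on a carbonyl carbon. Among the compounds with values here, no measured pair shows an aromatic ring at this position, so the step from compound 1 to compound 2 only tells that the read-out is sensitive here, not which way a ring will move it. Because compound 2 already stands at 0.54 nM, a move upward from it is the more likely outcome, and a moderate rise is expected, roughly a 9.3-fold higher number from compound 2 to compound 3 (0.97 log units; beyond the scatter). For compound 3 the estimate is 5 nM, between 0.8 nM and 30 nM.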

Compound 3, half-maximal effective concentration: 11 nM
The estimate for compound 3 lay 2.2-fold (0.34 log units) below the measured number, and the stated range covers the measured number.
By their numbers in this assay, from the lowest: compound 2; then compounds 3 and 1 (each within the scatter of the next).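

In this assay, replacing the open-chain group with the five-membered aromatic ring with 2 hetero atoms gives a 20-fold higher number from compound 2 to compound 3 (1.31 log units; beyond the scatter), even though the two groups match in heavy-atom count and in hydrogen-bond donors and acceptors. Those counts therefore do not alone set the read-out at this carbonyl carbon, and the low number of compound 2 goes with the particular open-chain group rather than with acyl groups of this size in general. The other step, a 1.4-fold lower number from compound 1 to compound 3 (0.13 log units; within the scatter), leaves the aromatic group and the group with the three-membered ring unseparated on this read-out, and no supporting data bear on the reason for either step.

Still open, going by these compounds, is whether the low number of compound 2 survives a longer chain or an amine in place of its hydroxyl group. On these data alone, the effect of the chlorine on the aromatic ring of compound 3 also remains open.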